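Sulfonyl aryl variation in a chemokine receptor binding series

The source may hold more compounds than are shown below. What is called first, only, known or untested is meant among the compounds shown, and "the series" means these compounds.

Measured so far:
compound 1 `O=C(NCc1ccc(CNS(=O)(=O)c2ccccc2Cl)cc1)c1cccnc1` gives 100 nM
compound 2 `O=C(NCc1ccc(CNS(=O)(=O)c2ccc(Cl)cc2)cc1)c1cccnc1` gives 1000 nM
compound 3 `O=C(NCc1ccc(CNS(=O)(=O)c2cccc3ccccc23)cc1)c1cccnc1` gives 1000 nM

In an assay on MDA-MB-231 cells for displacement of a labelled ligand from C-X-C chemokine receptor type 4 (Homo sapiens), read by fluorescence and microscopy, with stated times of 10 min and 30 min (on this read-out higher numbers stand for an effect only at larger amounts of compound and lower numbers for an effect already at smaller amounts), compound 3 stands level with compound 2, the two together at the highest numbers of the three, since no change at the digits printed from compound 2 to compound 3 (within the scatter); against compound 1 the gap is a 10-fold higher number from compound 1 to compound 3 (1.00 log units; beyond the scatter). Compound 4 `O=C(NCc1ccc(CNS(=O)(=O)c2ccc(F)cc2)cc1)c1cccnc1` is the next member. Change from compound 3: 4-fluorophenyl in place of naphthalen-1-yl on a sulfonyl sulfur. Within the data shown here, two measured steps bear on it. The step of no change at the digits printed from compound 2 to compound 3 (within the scatter) shows that the exchange of 4-chlorophenyl for naphthalen-1-yl left the number unchanged, and a 10-fold higher number from compound 1 to compound 2 (1.00 log units; beyond the scatter) shows that 4-chlorophenyl gives a clearly higher number than 2-chlorophenyl. Compound 4 carries 4-fluorophenyl, nearest in kind to the 4-chlorophenyl of compound 2, so the expected step of no change at the digits printed from compound 3 to compound 4 (within the scatter) is none beyond the scatter. Compound 4 is estimated at 1000 nM, with a range from 300 nM to 3000 nM.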

Compound 4, effective concentration (reported as EC, without a stated level of effect): 100 nM
Compound 4: middle estimate off by 10-fold (1.00 log units), on the high side, and the stated range ends above it.
By their numbers in this assay, from the lowest: compounds 1 and 4 (each within the scatter of the next); then compounds 2 and 3 (each within the scatter of the next).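

On the sulfonyl sulfur the halogen itself matters: fluoro in place of chloro on an aromatic carbon gives a 10-fold lower number from compound 2 to compound 4 (1.00 log units; beyond the scatter) and separates two groups that differ only in that atom. Naphthalen-1-yl and 4-chlorophenyl had matched, yet 4-fluorophenyl gives a 10-fold lower number from compound 3 to compound 4 (1.00 log units; beyond the scatter) as well. Against 2-chlorophenyl there is no change at the digits printed from compound 1 to compound 4 (within the scatter) so the lower numbers here are reached by two different aryl groups, one chlorinated and one fluorinated.

Open, from the compounds shown here alone, is how an unsubstituted phenyl, 2-fluorophenyl or 4-bromophenyl would read on the same sulfur. No measured evidence accounts for these steps.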